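Nitro to cyano exchange on the shared core

The source may hold more compounds than are shown below. What is called first, only, known or untested is meant among the compounds shown, and "the series" means these compounds.

Compound 1 `O=c1ccoc2cc(OCc3cn(Cc4ccccc4)nn3)ccc12` and compound 2 `O=c1ccoc2cc(OCc3cn(Cc4ccc([N+](=O)[O-])cc4)nn3)ccc12` share one core and differ only by a nitro group. In a functional assay on SW480 cells (Homo sapiens) for cytotoxicity, read by MTT assay, with a stated time of 48 h (on this read-out lower numbers stand for stronger inhibition and higher numbers for weaker inhibition), compound 1 gives 42900 nM, and compound 2 gives 19300 nM. Going by the values given here, the step of a 2.2-fold lower number from compound 1 to compound 2 (0.35 log units; beyond the scatter), nitro in place of hydrogen on an aromatic carbon, is the only measured step. Compound 2 thus stands with the lowest of the two numbers, compound 1 being its nearest neighbour.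

Compound 3 `N#Cc1ccc(Cn2cc(COc3ccc4c(=O)ccoc4c3)nn2)cc1` is not yet measured. It differs from compound 2 by cyano in place of nitro on an aromatic carbon, para to a large group; cut one bond further out, the change reads 4-nitrophenyl to 4-cyanophenyl. Among the compounds with values here, no measured compound carries a cyano at this position, and no measured step compares two different substituents there. Within the data shown here, the only related step, a 2.2-fold lower number from compound 1 to compound 2 (0.35 log units; beyond the scatter), shows that placing a group on that carbon moves the number modestly downward. Swapping one substituent for another at the same carbon is expected to move the number less than the change from hydrogen did, so the step from compound 2 to compound 3 in this assay is estimated at a 1.3-fold higher number from compound 2 to compound 3 (0.11 log units; within the scatter), within the scatter. Compound 3 is therefore expected to give about 25000 nM in this assay, in the range 10000 nM to 60000 nM.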

Compound 3, half-maximal inhibitory concentration: > 100000 nM
Compound 3: no number, only a limit (the forecaster's own chance of this, stated with the estimate: 5%); middle value at least 4.0-fold (0.60 log units) away from the limit.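

In this assay compound 3 carries no number, only a limit of the assay: the limit of > 100000 nM in this assay, at which 1 of the 3 values shown sits. The change from 4-nitrophenyl to 4-cyanophenyl gives an at least 5.1-fold higher number from compound 2 to compound 3 (0.71 log units; beyond the scatter), so at this carbon, para to a large group, the identity of the group counts and not merely the presence of one; this swap moves the number further than the first substitution did, a 2.2-fold lower number from compound 1 to compound 2 (0.35 log units; beyond the scatter). Measured against hydrogen, the two groups also part in direction: nitro lowers the number, whereas cyano gives an at least 2.3-fold higher number from compound 1 to compound 3 (0.36 log units; beyond the scatter), so a substituent on this carbon does not by itself bring a lower number in this series of three.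

From the compounds shown here alone, with compound 3 held at a limit, the full size of both new steps stays open. Three compounds in a single cell assay cannot separate possible explanations for the parting of the two groups. The compounds shown also leave open whether an amine, a carboxylic acid or a methoxy group on this carbon would side with compound 2 or with compound 3.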